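Swapping cyclopentyl for ethyl on a piperazine nitrogen

A few compounds are considered here, and "the series" means these few. Any claim that something is new, unique, unknown or untested is made for them only; others in the source may bear on it.

Among the measured compounds shown here, compound 2 `CN(C)Cc1ccc(CNc2nc(N3CCN(C4CCCC4)CC3)c3ncn(CCCN4CCCC4)c3n2)cc1` is one of three compounds measured in an ADME assay on microsomes from liver (Homo sapiens) for metabolic stability, read by LC-MS, with a stated time of 60 min (a lower number here means slower removal, a higher number faster removal of the compound), where compound 2 gives 13.6 mL.min-1.g-1. Of the three numbers this is the second highest. Compound 1 `CCN1CCN(CCCn2cnc3c(N4CCN(CC)CC4)ncnc32)CC1` gives 7.81 mL.min-1.g-1, and this lies within the scatter of the number for compound 2. For the measured compounds named here, compound 3 `Fc1ccc(CNc2nc(N3CCN(C4CCCC4)CC3)c3ncn(CCCN4CCCC4)c3n2)cc1` gives 38.8 mL.min-1.g-1, and the step of a 2.9-fold higher number from compound 2 to compound 3 (0.46 log units; beyond the scatter) is the only single-point change measured so far; it concerns fluoro in place of (dimethylamino)methyl on an aromatic carbon and does not touch the ring nitrogen considered next.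

Compound 4 `CCN1CCN(c2nc(NCc3ccc(CN(C)C)cc3)nc3c2ncn3CCCN2CCCC2)CC1` differs from compound 2 in one place: ethyl in place of cyclopentyl on an amine nitrogen in a ring. Going by the values given here, no measured step covers this change. Compound 1 also carries the ethyl group on that ring nitrogen, but it differs from compound 2 in several other places as well, so its value alone cannot be read as the effect of this change. Without a directly relevant step, no shift beyond the scatter is expected: the estimated step is a 1.4-fold lower number from compound 2 to compound 4 (0.16 log units; within the scatter). Compound 4 is therefore expected to give about 9.5 mL.min-1.g-1, in a range from 4.5 mL.min-1.g-1 to 20 mL.min-1.g-1.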

Compound 4, intrinsic clearance in microsomes: 7.1 mL.min-1.g-1
Compound 4: the middle estimate sits 1.3-fold (0.13 log units) above what was measured; the measured number falls inside the stated range.
By their numbers in this assay, from the lowest: compounds 4, 1 and 2 (each within the scatter of the next); then compound 3.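

Among the compounds shown here, the step of a 1.9-fold lower number from compound 2 to compound 4 (0.28 log units; within the scatter) in this assay is the first direct reading of ethyl in place of cyclopentyl on this amine nitrogen in a ring. Compound 1 also carries ethyl there but differs elsewhere, whereas this pair shares everything else, so the two numbers can be compared directly and cannot be told apart. At this position, then, the loss of the five-membered carbon ring gives no clear shift in this read-out, and nothing available explains why.

On these data alone, whether a different group on this nitrogen, such as an acetyl, a hydroxyethyl chain or a bare hydrogen, would move the number beyond the scatter remains open. So does whether ethyl would behave the same way alongside the fluoro group of compound 3.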